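Pentyl in place of amino: a probe on the glycinamide chain

The source may report more compounds than this note shows. Statements on the series, on what has been measured and on what is new or still open speak of the compounds shown alone.

Measured so far:
- compound 1, `CN(C(=O)CNC(=O)CN1CCCCC1)c1ccc(Cl)cc1C(=O)c1ccccc1Cl`: > 100 mg/kg
- compound 2, `CC(C)NCC(=O)NCC(=O)N(C)c1ccc(Cl)cc1C(=O)c1ccccc1Cl`: 13 mg/kg
- compound 3, `CN(C(=O)CNC(=O)CN)c1ccc(Cl)cc1C(=O)c1ccccc1Cl`: 27.7 mg/kg

Three compounds share a core and differ only in the group on a saturated chain carbon bound to a carbonyl carbon. In a functional assay on the whole organism with Mus musculus as the target, in the rotarod test (on this read-out lower numbers stand for an effect already at smaller amounts and higher numbers for an effect only at larger amounts of compound), compound 1 reaches only the limit > 100 mg/kg, so its value is a limit and not a number. Compound 2 gives 13 mg/kg and compound 3 gives 27.7 mg/kg; among the two numbers compound 3 stands highest, with a 2.1-fold higher number from compound 2 to compound 3 (0.33 log units; beyond the scatter). The two steps from compound 1, an at least 7.6-fold lower number from compound 1 to compound 2 (0.88 log units; beyond the scatter) and an at least 3.6-fold lower number from compound 1 to compound 3 (0.55 log units; beyond the scatter), are at least modest.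

Compound 4, `CCCCCCC(=O)NCC(=O)N(C)c1ccc(Cl)cc1C(=O)c1ccccc1Cl`, has not yet been measured. The change is pentyl in place of amino on a saturated chain carbon bound to a carbonyl carbon. Among the compounds with values here, no measured step removes the amine nitrogen altogether, so none bears on it directly; the steps seen concern only which amine is present. Since compound 1 also carries an amine yet sits at the limit of > 100 mg/kg in this assay, at which 1 of the 3 values shown sits, the data give no clear direction. A somewhat higher number is expected: compound 4 is estimated at 50 mg/kg, between 15 mg/kg and 150 mg/kg, which means an expected step of a 1.8-fold higher number from compound 3 to compound 4 (0.26 log units; within the scatter).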

Compound 4, dose for half-maximal effect: 70 mg/kg
The estimate for compound 4 lay 1.4-fold (0.15 log units) below the measured number; the measured number falls inside the stated range.
By their numbers in this assay, from the lowest: compound 2; then compound 3; then compound 4. At a limit, above all of these: compound 1.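

In this assay pentyl in place of an amine gives a 2.5-fold higher number from compound 3 to compound 4 (0.40 log units; beyond the scatter) and a 5.4-fold higher number from compound 2 to compound 4 (0.73 log units; beyond the scatter). An amine nitrogen at this place is therefore not needed for a number to be reached, although compound 2 and compound 3, with their small amines, both give lower numbers than compound 4. Compound 1 also carries an amine and goes against that order, and its value is a limit: the limit of > 100 mg/kg in this assay, at which 1 of the 4 values shown sits. Going by these compounds, with that limit, the step reads an at least 1.4-fold lower number from compound 1 to compound 4 (0.15 log units; that floor lies within the scatter), so its true size stays open.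

The change removes the amine and adds carbon atoms at once, and the two effects stay unseparated. Neither a shorter chain such as ethyl nor a pentyl chain ending in an amine or a carboxylic acid is among the compounds shown.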